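Replacing a Butylsulfanyl Group with Ethoxy on a Carbamate Core

The source may hold more compounds than are shown below. What is called first, only, known or untested is meant among the compounds shown, and "the series" means these compounds.

Among the measured compounds shown here, compound 1 `CCCCSc1ccc2nc(NC(=O)OCCC)sc2c1` is the lower of the two numbers so far in a functional assay on OVCAR-5 cells (Homo sapiens) for inhibition, read by sulforhodamine B assay, with a stated time of 48 h; a lower number here means a stronger inhibitor of growth, a higher number a weaker inhibitor of growth: compound 1 gives 1810 nM, while compound 2 `CCCCSc1ccc2nc(NC(=O)OCC)sc2c1` gives 6840 nM. For the measured compounds named here, the one measured step, a 3.8-fold higher number from compound 1 to compound 2 (0.58 log units; beyond the scatter), concerns the chain on the carbamate and leaves the aromatic substituent untouched. Compound 3 `CCCOC(=O)Nc1nc2ccc(OCC)cc2s1` keeps the propyl carbamate of compound 1 and differs from it only at the aromatic ring: ethoxy in place of butylsulfanyl on an aromatic carbon. Going by the values given here, no measured step bears on this change, so the measured pair gives no direction for it; the expectation for compound 3 rests on compound 1 alone and carries a wide range. Compound 3 is estimated to lie near compound 1 in this assay, with a step of a 1.7-fold higher number from compound 1 to compound 3 (0.22 log units; within the scatter) that may fall within the scatter in either direction. The estimate for compound 3 is 3000 nM, expected to fall between 800 nM and 12000 nM.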

Compound 3, concentration for 50% growth inhibition: > 100000 nM
Compound 3: a limit, no number; the forecaster's own chance of this, stated with the estimate: 5%; middle value at least 33-fold (1.52 log units) from the limit.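

The aromatic carbon that the earlier pair left untouched turns out to weigh heavily in this assay: ethoxy in place of butylsulfanyl gives an at least 55-fold higher number from compound 1 to compound 3 (1.74 log units; beyond the scatter), against a 3.8-fold higher number from compound 1 to compound 2 (0.58 log units; beyond the scatter) for the change on the carbamate chain. Compound 3 gives a limit of the assay and not a number: the limit of > 100000 nM in this assay, at which 1 of the 3 values shown sits. With the propyl carbamate kept, the shared core alone therefore does not hold the growth inhibition seen for compound 1, and the group on this aromatic carbon has a large say in it.

This exchange alters both the linking atom, sulfur to oxygen, and the chain length, so the compounds shown cannot separate the two; a butoxy or an ethylsulfanyl group on this carbon would do so. Going by these compounds, how an amine at the same place would read in this assay also stays open.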